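Removing the Ring Hydroxymethyl from Compound 3

This account rests on a few compounds, and the source may have more. Where it says the series, first, only, none or still open, it means among the compounds named here.

- Compound 1 (`CCCCCCCCCCCCCCCC(=O)C[C@H](COP(=O)(O)O[C@H]1[C@@H](O)[C@@H](O)[C@H](O)C[C@H]1O)C(=O)CCCCCCCCCCCCCCC`) reads 10000 nM in a functional assay on MCF7 cells (Homo sapiens) for inhibition; a higher number here means a weaker inhibitor, a lower number a stronger inhibitor
- Compound 2 (`CCCCCCCCCCCCCCCCCCOC[C@H](COP(=O)(O)O[C@@H]1[C@H](O)[C@@H](CO)[C@@H](O)[C@H](O)[C@@H]1O)OC`) reads 5000 nM
- Compound 3 (`CCCCCCCCCCCCCCCCCCOC[C@H](COP(=O)(O)O[C@@H]1[C@H](O)[C@@H](CO)[C@@H](O)[C@H](O)[C@@H]1O)n1ccnc1`) reads 2000 nM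

Compound 3 has the lowest number of the three in this assay and is the strongest inhibitor among them. Compound 4 (`CCCCCCCCCCCCCCCCCCOC[C@H](COP(=O)(O)O[C@H]1[C@@H](O)[C@@H](O)[C@H](O)C[C@H]1O)n1ccnc1`) departs from it in one place. The change is hydrogen in place of hydroxymethyl on a saturated ring carbon. Within the data shown here, no measured step covers this change. Among the measured compounds shown here, the only measured step (a 2.5-fold lower number from compound 2 to compound 3 (0.40 log units; beyond the scatter)) is modest and lies on a chain carbon, not on the ring. Compound 1 also lacks the hydroxymethyl and reads 10000 nM in this assay while differing from compound 4 in other places too, which makes it a weak guide. The data therefore give no ground for expecting a change beyond the scatter, though a shift of modest size towards a higher number remains possible. The estimated change is small (a 1.3-fold higher number from compound 3 to compound 4 (0.10 log units; within the scatter)). The expected reading for compound 4 in this assay is 2500 nM (range 800 nM to 8000 nM).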

Compound 4, half-maximal inhibitory concentration: 6000 nM
For compound 4 the middle estimate is 2.4-fold (0.38 log units) below the measured one; the measured number falls inside the stated range.
By their numbers in this assay, from the lowest: compound 3; then compounds 2, 4 and 1 (each within the scatter of the next).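

In this assay the ring position proves to matter: the swap of hydroxymethyl for hydrogen on the saturated ring carbon gives a 3.0-fold higher number from compound 3 to compound 4 (0.48 log units; beyond the scatter) and so takes back the gain seen on the chain carbon in a 2.5-fold lower number from compound 2 to compound 3 (0.40 log units; beyond the scatter) for this pair of changes. Among these compounds, the hydroxymethyl is therefore the first ring group here whose removal is seen on its own, and the step is modest but beyond the scatter, with compound 3 keeping the lowest number. The data on hand offer no measurement that accounts for this step.

The compounds shown leave open whether a methyl, an aminomethyl or a carboxylic acid on this ring carbon would hold the number of compound 3. They also leave open whether the methoxy group in place of 1H-imidazol-1-yl would shift the number by as much on the ring without hydroxymethyl.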